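The source may hold more compounds than are shown below. What is called first, only, known or untested is meant among the compounds shown, and "the series" means these compounds.

Measured so far:
Compound 1, `Cn1ccc(-c2cccc3c2CCC3c2ncc[nH]2)n1`, in a functional assay on CHO cells for agonist activity at Alpha-1A adrenergic receptor (Homo sapiens), read by FLIPR and calcium flux; a lower number here means that less compound is needed, a higher number that more compound is needed for the effect: > 1300 nM; this is a limit of the assay, not a number.
Compound 2, `CS(=O)(=O)Nc1cccc2c1CCCC2c1ncc[nH]1`, in this assay: 2150 nM; 142 nM; 234 nM (3 entries).

Compound 1 thus stands at the edge of what this assay reports; it carries only a limit of > 1300 nM in this assay, at which 1 of the 2 values shown sits, and a further entry without a single number. Compound 2 has several entries (the several entries of compound 2 in this assay, 2150 nM; 142 nM; 234 nM (3 entries)), which spread widely among themselves. For the measured compounds named here, no step between measured compounds differing in one place is available, so nothing measured bears directly on the move from compound 1 to compound 3.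

Compound 3, `Cn1cc(-c2cccc3c2CCC3c2ncc[nH]2)cn1`, differs from compound 1 by 1-methyl-1H-pyrazol-4-yl in place of 1-methyl-1H-pyrazol-3-yl on an aromatic carbon. As compound 1 gives only a limit, the direction of the change cannot be fixed from the data. The step that the limit leaves unreadable from compound 1 to compound 3 is expected to be modest, not clearly beyond the scatter in either direction. Compound 3 is estimated at 2500 nM in this assay, with a range from 600 nM to 10000 nM, and a fair chance that compound 3 likewise returns only a limit.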

Compound 3, half-maximal effective concentration: > 2900 nM
Compound 3: a limit, no number (the forecaster's own chance of this, stated with the estimate: 50%); at least 1.1-fold (0.06 log units) between middle value and limit.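

Compound 3 gives > 2900 nM in this assay as a limit of the assay. Compound 1 likewise gives > 1300 nM in this assay as a limit of the assay. For the compounds shown here, with only limits on both sides, no step from compound 1 to compound 3 can be read. Still open, going by these compounds, is whether 1-methyl-1H-pyrazol-4-yl and 1-methyl-1H-pyrazol-3-yl differ at all here, and what number either compound would give.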